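A Chloro Substituent Added to Compound 1

This account rests on a few compounds, and the source may have more. Where it says the series, first, only, none or still open, it means among the compounds named here.

Compound 1 `CCC(=O)Nc1cccc(Oc2nc(Nc3ccc(N4CCN(C)CC4)cc3)ncc2Cl)c1` stands highest of the two measured compounds: in an assay on isolated protein for inhibition of NUAK family SNF1-like kinase 1 (Homo sapiens), read by ADP-Glo, with a stated time of 60 min, tested at 10 uM, in the presence of a further agent that is not named here (on this read-out higher numbers stand for more inhibition at the one concentration tested (going by the name of the read-out) and lower numbers for less inhibition), compound 1 gives 92.9%, while compound 2 `CCC(=O)Nc1cccc(Oc2nc(Nc3ccc(N(CC)CC)cc3)ncc2Cl)c1` gives 54.4%. Among the measured compounds shown here, the single measured step, a number 38.5 percentage points lower from compound 1 to compound 2 (beyond the scatter), concerns the amine on the six-membered aromatic ring of carbon only. Compound 3 `CCC(=O)Nc1cccc(Oc2nc(Nc3ccc(N4CCN(C)CC4)cc3Cl)ncc2Cl)c1` differs from compound 1 elsewhere: chloro in place of hydrogen on an aromatic carbon. The chloro group enters ortho to a large group and meta to the 4-methylpiperazin-1-yl group, which compound 3 keeps. For the measured compounds named here, no measured step touches this position, so the step from compound 1 to compound 2 does not bear directly on the change, and the data give no further guide. Because compound 1 gives 92.9% while carrying the 4-methylpiperazin-1-yl group, which compound 3 retains, the expected step of a number 4.9 percentage points lower from compound 1 to compound 3 (within the scatter) is small, within the scatter. Compound 3 is therefore estimated at 88%, within 70% to 98%.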

Compound 3, a percentage reported as inhibition, at one concentration (the size of the read-out at that concentration, not a potency): 71.5%
The estimate for compound 3 lay 16.5 percentage points above the measured number; the range from low to high includes it.
By their numbers in this assay, from the lowest: compound 2; then compound 3; then compound 1.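

In this assay the aromatic carbon ortho to a large group and meta to a 4-methylpiperazin-1-yl group responds to substitution: chloro in place of hydrogen there gives a number 21.4 percentage points lower from compound 1 to compound 3 (beyond the scatter) and so this position is not indifferent to the change. Among the compounds shown here, this is the first measured step at this position, and it shows that keeping the 4-methylpiperazin-1-yl group does not by itself hold the number seen for compound 1 once a single chlorine enters. No measurement at hand accounts for the lower number. From the compounds shown here alone, whether it belongs to chloro in particular or to any group on this carbon stays open, and a fluoro, methyl or methoxy group there would help to tell these apart. Also open, going by these compounds, is whether chloro here has the same effect with diethylamino in place of 4-methylpiperazin-1-yl.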